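This account rests on a few compounds, and the source may have more. Where it says the series, first, only, none or still open, it means among the compounds named here.

Measured so far:
compound 1 `CONC(=O)CCc1ccccc1`: >= 200000 nM
compound 2 `CC1=C(O)CC(Cc2ccccc2)C1=O`: > 200000 nM
compound 3 `O=c1c(O)c(NCc2ccccc2)c1=O`: >= 200000 nM

All three compounds were tested in a physicochemical assay for solubility, read by LC-MS, in phosphate buffer, measured as kinetic solubility, with a stated time of 24 h, at pH 7.4, tested at 200 uM; on this read-out higher numbers stand for higher solubility and lower numbers for lower solubility. None of these readings is a true number, so the three cannot be put in any order. Compound 2 reads > 200000 nM, and this is a limit of the assay. Compound 1 reads >= 200000 nM, which is also a limit. Compound 3 reads >= 200000 nM, again a limit.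

The compound still to be measured, compound 4 `O=C1C=C(O)CC1Cc1ccccc1`, differs from compound 2 in one place: hydrogen in place of methyl on a double-bonded ring carbon. That carbon belongs to a five-membered non-aromatic ring of carbon only.

For the measured compounds named here, no pair of measured compounds shows what a change like this does in this assay, so there is no measured step to draw on. The expectation is no step beyond the usual scatter of repeated measurements, in either direction, because compound 2 reads > 200000 nM. The estimated change is a number no higher from compound 2 to compound 4 (the limit leaves the size open). For compound 4 the estimated value is 200000 nM, with an expected range from 120000 nM to 220000 nM. The reading may well turn out to be only a limit again.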

Compound 4, solubility: 195000 nM
Compound 4: middle estimate off by 1.0-fold (0.01 log units), on the high side, and the stated range covers the measured number.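

The methyl on the double-bonded ring carbon can give way to hydrogen while the reading stays a high one: in this assay, this single change gives an at least 1.0-fold lower number from compound 2 to compound 4 (0.01 log units; that floor lies within the scatter). Compound 4 reads 195000 nM, and this is the only true number among the four compounds shown, so the series now has a measured reading rather than limits alone. Compound 2 reads > 200000 nM, which is a limit, so the step has only a floor and its real size stays unknown: the limit of > 200000 nM in this assay, at which 1 of the 4 values shown sits.

Going by these compounds, how much the methyl itself matters in this assay therefore remains open, as the floor lies within the scatter and a larger true step is not ruled out by a reading that is a limit. Also open, on these data alone, is what a longer chain such as ethyl, an amine or a carboxylic acid on that same ring carbon would give, and whether the swap of methyl for hydrogen would behave the same way on the cores of compound 1 and compound 3.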